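Fluoro in place of hydrogen: compound 1 to compound 4

This account rests on a few compounds, and the source may have more. Where it says the series, first, only, none or still open, it means among the compounds named here.

Three compounds sharing one core have numbers in a functional assay on Caco-2 cells (Homo sapiens) for inhibition, read by MTT assay, with a stated time of 48 h; on this read-out higher numbers stand for weaker inhibition of growth and lower numbers for stronger inhibition of growth. Compound 1 `CN1CC[C@H](c2c(O)cc(O)c3c(=O)cc(/C=C/c4ccccc4)oc23)[C@H](O)C1` gives 3700 nM, compound 2 `CN1CC[C@H](c2c(O)cc(O)c3c(=O)cc(/C=C/c4ccc(Cl)cc4)oc23)[C@H](O)C1` gives 5600 nM and compound 3 `CN1CC[C@H](c2c(O)cc(O)c3c(=O)cc(/C=C/c4c(F)c(F)c(F)c(F)c4F)oc23)[C@H](O)C1` gives 8000 nM. Compound 1 holds the lowest of the three numbers, but it is separated beyond the scatter from compound 3 only.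

Compound 4 `CN1CC[C@H](c2c(O)cc(O)c3c(=O)cc(/C=C/c4cccc(F)c4)oc23)[C@H](O)C1` carries one change from compound 1: fluoro in place of hydrogen on an aromatic carbon. This is fluoro in place of hydrogen on an aromatic carbon, meta to a large group, so that phenyl becomes 3-fluorophenyl.

Among the measured compounds shown here, two measured steps bear on it. The chloro change, which also replaces a single hydrogen on an aromatic carbon, is a 1.5-fold higher number from compound 1 to compound 2 (0.18 log units; within the scatter). The change to 2,3,4,5,6-pentafluorophenyl is a 2.2-fold higher number from compound 1 to compound 3 (0.33 log units; beyond the scatter). Between those two end points the data show a 1.4-fold higher number from compound 2 to compound 3 (0.15 log units; within the scatter). For the measured compounds named here, no compound with a single fluoro has been measured, so the closest guide is the single chloro change, with the modest pentafluorophenyl step as the outer case. No step beyond the scatter is expected in this assay, with a slight lean towards a higher number. The expected step is a 1.2-fold higher number from compound 1 to compound 4 (0.07 log units; within the scatter). The estimated value for compound 4 is 4300 nM, with an expected range from 2600 nM to 7000 nM.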

Compound 4, concentration for 50% growth inhibition: 8000 nM
The estimate for compound 4 lay 1.9-fold (0.27 log units) below the measured number; measured number outside the range, above it.
By their numbers in this assay, from the lowest: compounds 1, 2, 3 and 4 (each within the scatter of the next, the first and the last beyond it).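

In this assay, among the compounds shown here, a single fluoro on an aromatic carbon, meta to a large group, gives a step beyond the scatter: a 2.2-fold higher number from compound 1 to compound 4 (0.33 log units; beyond the scatter) for this one replacement of hydrogen, whereas the single chloro of compound 2 stayed within the scatter of compound 1. The fully fluorinated ring adds nothing that can be seen over this one fluoro, with no change at the digits printed from compound 3 to compound 4 (within the scatter) in the same assay, so 3-fluorophenyl and 2,3,4,5,6-pentafluorophenyl are not told apart on this read-out. With a 1.4-fold higher number from compound 2 to compound 4 (0.15 log units; within the scatter) as well, 3-fluorophenyl and 4-chlorophenyl are not separated either, so compound 1 with its plain phenyl stands apart from compounds 3 and 4 but not from compound 2, which goes against any reading that every substituent on this ring moves the number beyond the scatter.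

Open, as far as these compounds go, is whether the step belongs to fluoro or to this ring place, which 4-fluorophenyl and 3-chlorophenyl would separate, and whether an amino group, a methoxy group or a carboxylic acid at the same carbon would follow compound 4 or return towards compound 1. Nothing at hand explains the step of compound 4 or ties it to any property of the fluoro group.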